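A few compounds are considered here, and "the series" means these few. Any claim that something is new, unique, unknown or untested is made for them only; others in the source may bear on it.

Working notes on a small series examined in a functional assay on Lu1 cells (Homo sapiens) for cytotoxicity; a lower number here means that less compound is needed, a higher number that more compound is needed for the effect.

Compound 1 `CCC[C@@H](OC(C)=O)C1=C(Br)[C@@](CI)(OC)OC1=O` opens the set. In this assay compound 1 gives > 20 ug/mL, which is a limit of the assay and not a number.

Compound 2 `CCC[C@@H](OC(C)=O)C1=C(Br)[C@@](OC)(C(Br)Br)OC1=O` is the second measured member. In this assay compound 2 gives > 20 ug/mL, again a limit of the assay rather than a measured number. Where compound 2 stands is therefore fixed only by the limit of > 20 ug/mL in this assay, at which 2 of the 2 values shown sit; compound 2 and compound 1 sit level at that limit, and no order between them can be read from what is shown.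

Compound 3 `CCC[C@@H](OC(C)=O)C1=C(Br)[C@](OC)(C(Br)Br)OC1=O` has not yet been tested. Relative to compound 2 the change is the two compounds have the same atoms and bonds and differ only in configuration as drawn: 1 of 2 stereo elements differ; a stereocentre at a saturated ring carbon is drawn S in compound 2 and R in compound 3. Going by the values given here, no measured step of this kind exists, so nothing is known about what a change of configuration alone does here.

Given that compound 2 sits at a limit, the step that the limit leaves unreadable from compound 2 to compound 3 is expected to be none beyond the scatter. Compound 3 is accordingly expected to give about 30 ug/mL, within a range from 15 ug/mL to 80 ug/mL, and most likely as a limit once more.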

Compound 3, concentration for half-maximal effect: > 20 ug/mL
Compound 3: only a limit was reported (the forecaster's own chance of this, stated with the estimate: 80%); the middle value lies beyond the limit too.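

No step from compound 1 or compound 2 to compound 3 can be read, because all three compounds rest at the same limit of the assay and no measured number separates them: the limit of > 20 ug/mL in this assay, at which 3 of the 3 values shown sit.

The compounds shown leave open whether the configuration at the saturated ring carbon, or dibromomethyl in place of iodomethyl, has any effect on cytotoxicity in this assay.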